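This account rests on a few compounds, and the source may have more. Where it says the series, first, only, none or still open, it means among the compounds named here.

Of the compounds shown here, two of a shared core have been measured in an assay for inhibition of Indoleamine 2,3-dioxygenase 1 (Homo sapiens), with stated times of 10 min and 60 min, tested at 100 uM; on this read-out lower numbers stand for a weaker effect and higher numbers for a stronger effect at the one concentration tested. Compound 1, `Nc1cccc(CNc2cc(C(F)(F)F)cc3[nH]ncc23)c1`, gives 55%. For the measured compounds named here, compound 2, `O=C(O)c1cccc(CNc2cc(C(F)(F)F)cc3[nH]ncc23)c1`, gives 17% and so stands as the lower of the two numbers; the step of a number 38 percentage points lower from compound 1 to compound 2 (beyond the scatter) is the only measured step, and it came with carboxy in place of amino on an aromatic carbon.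

Compound 3, `OC1CCCC(Nc2cccc(CNc3cc(C(F)(F)F)cc4[nH]ncc34)c2)C1`, has not yet been measured. It differs from compound 2 in one place: (3-hydroxycyclohexyl)amino in place of carboxy on an aromatic carbon. The carboxy that leaves is the very group whose arrival lowered the number by a large step, and what enters is again a nitrogen-bearing group on that aromatic carbon, as in compound 1. The step from compound 1 to compound 2 is therefore the one that bears on this change, and it suggests that removing carboxy should move the number back upward by a step well beyond the scatter.

For compound 3 the estimate in this assay is 50%, with a range from 25% to 75%, which means an expected step of a number 33 percentage points higher from compound 2 to compound 3 (beyond the scatter).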

Compound 3, a percentage reported as inhibition, at one concentration (the size of the read-out at that concentration, not a potency): 2%
For compound 3 the middle estimate is 48 percentage points above the measured one, and the stated range ends above it.
By their numbers in this assay, from the lowest: compound 3; then compound 2; then compound 1.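

In this assay, a nitrogen on this aromatic carbon, meta to a large group, is not enough on its own to keep the number high: 3-hydroxycyclohexyl in place of hydrogen on that nitrogen gives a number 53 percentage points lower from compound 1 to compound 3 (beyond the scatter). The comparison with the carboxy compound points the same way, since (3-hydroxycyclohexyl)amino in place of carboxy gives a number 15 percentage points lower from compound 2 to compound 3 (beyond the scatter), so the number does not recover when carboxy leaves and a substituted nitrogen enters. At this position, then, what is attached to the nitrogen matters as well as the presence of the nitrogen, and nothing available here explains the fall.

The compounds shown leave open whether the fall belongs to the cyclohexyl ring, to its hydroxy group, or to both, a question that a plain cyclohexylamino group and a much smaller methylamino group at the same place could help to separate. They also leave open how an amide on this nitrogen would compare, and, with one concentration per compound, these numbers give no potency for any of the three.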